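Swapping the benzyl substituent on a shared core

A few compounds are considered here, and "the series" means these few. Any claim that something is new, unique, unknown or untested is made for them only; others in the source may bear on it.

In a physicochemical assay for acid dissociation, compound 2 `COc1ccc(F)cc1CNCCCNc1ccnc2cc(-c3ccc(C(F)(F)F)cc3)ccc12` gives 9.47. Compound 1 `COc1cccc(CNCCCNc2ccnc3cc(Cc4ccc(F)cc4)ccc23)c1O` gives 9.47, so compound 2 stands level with compound 1 within the scatter. Compound 3 `COc1cccc(CNCCCNc2ccnc3cc(-c4ccc(C(F)(F)F)cc4)ccc23)c1O` is not yet measured; it differs from compound 2 by 2-hydroxy-3-methoxyphenyl in place of 5-fluoro-2-methoxyphenyl on a saturated chain carbon bound to an amine nitrogen. Within the data shown here, no measured pair shows this exact step. Because compound 1 already carries the 2-hydroxy-3-methoxybenzyl group and gives 9.47, the expected step is no change at the digits printed from compound 2 to compound 3 (within the scatter), nothing beyond the scatter. Compound 3 is therefore estimated at 9.47, with a range from 9.15 to 9.8.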

Compound 3, acid dissociation constant: 9.47
The estimate for compound 3 equals the measured number at the digits printed; the measured number falls inside the stated range.
By their numbers in this assay, from the lowest: compounds 1, 2 and 3 (each within the scatter of the next).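

In this assay the step for 2-hydroxy-3-methoxyphenyl in place of 5-fluoro-2-methoxyphenyl on a saturated chain carbon bound to an amine nitrogen is no change at the digits printed from compound 2 to compound 3 (within the scatter) and the step for 4-(trifluoromethyl)phenyl in place of 4-fluorobenzyl on an aromatic carbon is no change at the digits printed from compound 1 to compound 3 (within the scatter). Each place is now seen changed alone, which compounds 1 and 2, differing in both, could not show. Nothing at hand explains this result. Still open, going by these compounds, is whether a carboxylic acid in place of 4-(trifluoromethyl)phenyl on an aromatic carbon, or a longer chain in place of 2-hydroxy-3-methoxyphenyl on a saturated chain carbon bound to an amine nitrogen, would shift the reading.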